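The compounds below may be only part of what the source reports. "The series", "measured", "known", "first", "only" and "open" are said of these compounds alone.

In an ADME assay on CHO cells (Cricetulus griseus) for inhibition, read by MTT assay (on this read-out lower numbers stand for stronger inhibition and higher numbers for weaker inhibition), compound 1 `CCN(CC)Cc1cccc(Nc2nc3ccccc3n2Cc2ccc(F)cc2)c1O` gives > 50000 nM, which is a limit of the assay and not a number. Going by the values given here, compound 2 `CCN(CC)Cc1cc(C)cc(Nc2nc3ccccc3n2Cc2ccc(F)cc2)c1O` gives 18700 nM, the lowest number measured so far. Compound 3 `CCN(CC)Cc1ccc(Nc2nc3ccccc3n2Cc2ccc(C#N)cc2)cc1O` stands higher at 39000 nM.

Compound 4 `CCN(CC)Cc1cc(C)cc(Nc2nc3ccccc3[nH]2)c1O` has not been measured. It differs from compound 2 in one place: hydrogen in place of 4-fluorobenzyl on an aromatic nitrogen. Hydrogen replaces 4-fluorobenzyl on an aromatic nitrogen, a much larger change than the only measured step, an at least 2.6-fold lower number from compound 1 to compound 2 (0.42 log units; beyond the scatter), where methyl replaced hydrogen on an aromatic carbon. Compound 4 keeps that methyl. Among the compounds with values here, every measured compound has a large group on the nitrogen in question, so no measured step shows directly what its loss does.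

Within the data shown here, with compound 2 at 18700 nM, the lowest number so far, a rise is more likely than a fall, and it would mean weaker inhibition. The expected change is a 2.1-fold higher number from compound 2 to compound 4 (0.33 log units; beyond the scatter), though this is uncertain. For compound 4, the estimated value is 40000 nM, with an expected range of 14000 nM to 90000 nM.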

Compound 4, half-maximal inhibitory concentration: > 50000 nM
Compound 4 was reported as a limit (the forecaster's own chance of this, stated with the estimate: 45%); at least 1.2-fold (0.09 log units) between middle value and limit.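

Going by these compounds alone, this is the first measured step at the aromatic nitrogen: in this assay, hydrogen in place of 4-fluorobenzyl gives an at least 2.6-fold higher number from compound 2 to compound 4 (0.42 log units; beyond the scatter), which means weaker inhibition. Compound 4 still carries the methyl found in compound 2, so that methyl alone does not keep the lower number once the 4-fluorobenzyl group is gone. As far as these compounds go, compound 4 gives > 50000 nM, which is a limit of the assay and not a number, so the full size of the step stays unknown, and the same limit recurs in the set: the limit of > 50000 nM in this assay, at which 2 of the 4 values shown sit.

The compounds shown leave open how much of the group on this nitrogen is needed, for instance whether a plain methyl, an unsubstituted benzyl or a longer chain ending in an amine would keep the number of compound 2. With this core, only 4-fluorobenzyl and hydrogen can be compared at this position.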